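Swapping methoxy for a hexyl chain on the shared core

The source may report more compounds than this note shows. Statements on the series, on what has been measured and on what is new or still open speak of the compounds shown alone.

Measured so far in a functional assay on MDA-MB-231 cells (Homo sapiens) for antiproliferative activity, with a stated time of 4 days; on this read-out higher numbers stand for weaker inhibition and lower numbers for stronger inhibition:
- compound 1 `COc1ccc(-c2[nH]c3ccc(OC)cc3c2C=O)cc1` gives 260 nM
- compound 2 `COc1ccc(-c2[nH]c3ccc(C)cc3c2C=O)cc1` gives 86 nM
- compound 3 `COc1ccc(-c2[nH]c3ccc(CC(C)C)cc3c2C=O)cc1` gives 72 nM

Compound 1 gives the highest number of the three. The two steps leading away from it are a 3.0-fold lower number from compound 1 to compound 2 (0.48 log units; beyond the scatter) and a 3.6-fold lower number from compound 1 to compound 3 (0.56 log units; beyond the scatter), each a modest lowering. Compound 4 `CCCCCCc1ccc2[nH]c(-c3ccc(OC)cc3)c(C=O)c2c1` differs from compound 1 by hexyl in place of methoxy on an aromatic carbon. Both measured steps that put an alkyl group in place of the methoxy lowered the number by a similar modest amount, while the change from one alkyl group to another gave a 1.2-fold lower number from compound 2 to compound 3 (0.08 log units; within the scatter). A modest lowering of the same kind is therefore expected in this assay, a 3.7-fold lower number from compound 1 to compound 4 (0.57 log units; beyond the scatter). Compound 4 is estimated at 70 nM, with a likely range from 30 nM to 160 nM.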

Compound 4, half-maximal inhibitory concentration: 7.4 nM
Compound 4: middle estimate off by 9.5-fold (0.98 log units), on the high side; measured number below the stated range.
By their numbers in this assay, from the lowest: compound 4; then compounds 3 and 2 (each within the scatter of the next); then compound 1.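

Alkyl groups at this position turn out not to be interchangeable: hexyl brings a 12-fold lower number from compound 2 to compound 4 (1.07 log units; beyond the scatter) and a 9.7-fold lower number from compound 3 to compound 4 (0.99 log units; beyond the scatter) in this assay, although the methyl and isobutyl groups of compounds 2 and 3 sit within the scatter of each other. Replacing methoxy with hexyl gives a 35-fold lower number from compound 1 to compound 4 (1.55 log units; beyond the scatter) and so a much larger drop than either smaller alkyl group gave. Nothing available here explains what the hexyl chain is doing.

Going by these compounds, whether the number keeps falling with a longer chain such as octyl remains open. So does the effect of a chain ending in an amine or a carboxylic acid at this place.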